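The compounds below may be only part of what the source reports. "The series", "measured", "known", "first", "only" and "open" are said of these compounds alone.

Of the compounds shown here, three sharing one core have been read in an ADME assay on HEK293 cells (Homo sapiens) for cytotoxicity, read by MTT assay, with a stated time of 48 h; on this read-out lower numbers stand for stronger inhibition and higher numbers for weaker inhibition. Compound 1 `CN(C)CCn1c(N)c(-c2nc3ccccc3[nH]2)c2nc(C#N)c(C#N)nc21`, with dimethylamino on its chain, gives 9730 nM. Compound 3 `CCN(CC)CCCn1c(N)c(-c2nc3ccccc3[nH]2)c2nc(C#N)c(C#N)nc21`, with a 3-(diethylamino)propyl chain, gives 7870 nM. Within the data shown here, these two are the only numeric values, and they stand level: a 1.2-fold lower number from compound 1 to compound 3 (0.09 log units; within the scatter). Compound 2 `CCCn1c(N)c(-c2nc3ccccc3[nH]2)c2nc(C#N)c(C#N)nc21`, which has no amino group on its chain, reads > 50000 nM, and this is a limit of the assay. The two steps that involve compound 2 are larger, an at least 5.1-fold higher number from compound 1 to compound 2 (0.71 log units; beyond the scatter) and an at least 6.3-fold lower number from compound 2 to compound 3 (0.80 log units; beyond the scatter), and both rest on (the limit of > 50000 nM in this assay, at which 1 of the 3 values shown sits).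

Compound 4 `CN1CCN(CCCn2c(N)c(-c3nc4ccccc4[nH]3)c3nc(C#N)c(C#N)nc32)CC1` differs from compound 3 in one place: 4-methylpiperazin-1-yl in place of diethylamino on a saturated chain carbon, three bonds along the chain from an aromatic nitrogen. Here 4-methylpiperazin-1-yl stands in place of diethylamino on a saturated chain carbon, three bonds along the chain from an aromatic nitrogen. Among the measured compounds shown here, the closest precedent is the exchange of one amino group for another, a 1.2-fold lower number from compound 1 to compound 3 (0.09 log units; within the scatter), which left the number within the scatter. The steps involving compound 2 have less bearing, since compound 4 keeps an amino group on its chain. For the measured compounds named here, no ring-bearing group has yet been read, so the range is kept wide. The expected step, a 1.4-fold higher number from compound 3 to compound 4 (0.15 log units; within the scatter), is not expected to stand clear of the scatter. For compound 4 the estimate in this assay is 11000 nM, with an expected range from 4500 nM to 30000 nM.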

Compound 4, half-maximal inhibitory concentration: 6260 nM
The estimate for compound 4 lay 1.8-fold (0.24 log units) above the measured number, and the stated range covers the measured number.
By their numbers in this assay, from the lowest: compounds 4, 3 and 1 (each within the scatter of the next). At a limit, above all of these: compound 2.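

In this assay, a ring-bearing amine on the chain leaves the number level with the open-chain amines, both against the diethylamino group it replaces (a 1.3-fold lower number from compound 3 to compound 4 (0.10 log units; within the scatter)) and against the shorter dimethylamino compound (a 1.6-fold lower number from compound 1 to compound 4 (0.19 log units; within the scatter)). Among the compounds shown, then, dimethylamino, diethylamino and 4-methylpiperazin-1-yl all stand within the scatter of one another, and a six-membered ring with a second nitrogen does not set compound 4 apart from compound 1 or compound 3. Among these compounds, only the step from the chain without an amino group is large (an at least 7.9-fold lower number from compound 2 to compound 4 (0.90 log units; beyond the scatter)), and this step rests on a limit and not on a number: the limit of > 50000 nM in this assay, at which 1 of the 4 values shown sits.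

From the compounds shown here alone, how a morpholin-4-yl group, a primary amine or a carboxylic acid at the end of the same chain would read remains open, as does the reading of 4-methylpiperazin-1-yl on a longer chain. Also open, going by these compounds, is how far compound 2 truly stands from the others, as its reading is only a limit.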